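The source may report more compounds than this note shows. Statements on the series, on what has been measured and on what is new or still open speak of the compounds shown alone.

Three related compounds have been measured in a physicochemical assay for solubility, read by HPLC, in phosphate buffer, measured as kinetic solubility, at pH 7.4; a higher number here means a more soluble compound, a lower number a less soluble compound. Compound 1 (`CCC(=O)c1cc(-c2ccc(Cl)cc2)n(-c2ccc(S(=O)(=O)N(C)C)cc2)c1C`) gives 1200 nM, compound 2 (`CC(=O)c1cc(-c2ccc(Cl)cc2)n(-c2ccc(S(N)(=O)=O)cc2)c1C`) gives 2700 nM, and compound 3 (`CCC(=O)c1cc(-c2ccc(F)cc2)n(-c2ccc(S(N)(=O)=O)cc2)c1C`) gives 29300 nM. Compound 3 therefore stands highest of the three, and its distance from each of the other two lies beyond the usual scatter of repeated measurements.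

Compound 4 (`CCC(=O)c1cc(-c2ccc(Cl)cc2Cl)n(-c2ccc(S(N)(=O)=O)cc2)c1C`) has not yet been measured. It differs from compound 3 in one place, with 2,4-dichlorophenyl in place of 4-fluorophenyl on an aromatic carbon of a five-membered aromatic ring with 1 nitrogen (2,4-dichlorophenyl in place of 4-fluorophenyl on an aromatic carbon).

Among the compounds with values here, no two measured compounds differ in just one place, so no clean step is available as a guide. There is only a loose hint from three compounds. Compound 1 (1200 nM) and compound 2 (2700 nM) carry chlorine where compound 3 carries fluorine, and both numbers lie lower than that of compound 3 (29300 nM), although both compounds also differ from it elsewhere.

On that hint, the expected change in this assay is a fall well beyond the scatter (a 15-fold lower number from compound 3 to compound 4 (1.17 log units; beyond the scatter)). Compound 4 is estimated at 2000 nM (expected range 500 nM to 8000 nM).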

Compound 4, solubility: 7700 nM
For compound 4 the middle estimate is 3.9-fold (0.59 log units) below the measured one; low and high end bracket the measured number.
By their numbers in this assay, from the lowest: compound 1; then compound 2; then compound 4; then compound 3.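

Within the data shown here, compound 3 and compound 4 give the first clean comparison in this set: in this assay, putting 2,4-dichlorophenyl in place of 4-fluorophenyl on the aromatic carbon next to the ring nitrogen gives a 3.8-fold lower number from compound 3 to compound 4 (0.58 log units; beyond the scatter). With everything else in the molecule held the same, this shows that the number responds to a change at this position alone, although the step is modest and lies only moderately beyond the usual scatter of repeated measurements. Nothing measured here explains why the number falls.

The step removes one fluorine and adds two chlorines in a single change, so the compounds shown cannot say how much of it belongs to the chlorine at the 4 position of the phenyl ring, how much to the chlorine at the 2 position, and how much to the loss of fluorine. On these data alone, it also remains open how this assay would respond to a quite different substituent on that phenyl ring, such as an amine or a carboxylic acid.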